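The source may report more compounds than this note shows. Statements on the series, on what has been measured and on what is new or still open speak of the compounds shown alone.

Three measured compounds make up the set. Compound 1 `CC(=O)Oc1cc2oc(-c3ccccc3)cc(=O)c2c(O)c1OC(C)=O` carries a hydrogen on the oxygen in question; in a functional assay on KB 3-1 cells (Homo sapiens), with a stated time of 1 h (on this read-out higher numbers stand for an effect only at larger amounts of compound and lower numbers for an effect already at smaller amounts), compound 1 gives 9700 nM. Compound 2 `CC(=O)Oc1cc2oc(-c3ccccc3)cc(=O)c2c(OCc2ccccc2)c1OC(C)=O` differs from compound 1 by benzyl in place of hydrogen on an oxygen on an aromatic ring; in this assay compound 2 gives 3700 nM. The step of a 2.6-fold lower number from compound 1 to compound 2 (0.42 log units; beyond the scatter) is the one point of reference for this change. Compound 3 `O=c1cc(-c2ccccc2)oc2cc(O)c(OCc3ccccc3)c(O)c12` rests on a different core; how that core differs from the core of compound 1 is not broken down here. In this assay compound 3 gives 1800 nM, the lowest number of the three.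

Compound 4 `O=c1cc(-c2ccccc2)oc2cc(O)c(OCc3ccccc3)c(OCc3ccccc3)c12` differs from compound 3 by benzyl in place of hydrogen on an oxygen on an aromatic ring. Among the compounds with values here, this is the same change as the one from compound 1 to compound 2, made at the same kind of place on the other core, so the expectation for compound 4 rests on the step of a 2.6-fold lower number from compound 1 to compound 2 (0.42 log units; beyond the scatter) alone. A step of about the same size is expected, a 2.6-fold lower number from compound 3 to compound 4 (0.41 log units; beyond the scatter), with the reservation that a single earlier step on a different core is a thin basis. On that footing compound 4 is estimated at 700 nM in this assay, with a likely range from 300 nM to 1600 nM.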

Compound 4, half-maximal effective concentration: 70000 nM
Compound 4: middle estimate off by 100-fold (2.00 log units), on the low side; measured number above the stated range.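

In this assay, benzyl in place of hydrogen on an oxygen on an aromatic ring gives a 39-fold higher number from compound 3 to compound 4 (1.59 log units; beyond the scatter), so on this core the change goes the opposite way from the earlier step, and the two steps do not agree: the same change on two cores in this assay, a 2.6-fold lower number (0.42 log units; beyond the scatter) from compound 1 to compound 2 and a 39-fold higher number (1.59 log units; beyond the scatter) from compound 3 to compound 4, 100-fold (2.01 log units) apart, beyond the scatter of two such steps

In this series, then, the effect of this change cannot be carried from the core of compound 1 to the core of compound 3, and a step read on one core is no guide to the other. Within the data shown here, with only one step on each core, this does not show which feature of the cores sets the direction, nor whether either step is typical of its own core.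

Open, from the compounds shown here alone, is whether a methyl group or a longer chain on the same oxygen would follow the step seen on each core. Also open, going by these compounds, is whether a benzyl carrying an amine or a carboxylic acid would behave like the plain benzyl.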